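A few compounds are considered here, and "the series" means these few. Any claim that something is new, unique, unknown or untested is made for them only; others in the source may bear on it.

Compound 1, `COc1ccc(C2N=C(SCc3ccc(Cl)cc3)NC(C)=C2C(=O)Nc2ccc(F)cc2)cc1OC`, gives 15.5%.
Compound 2, `COc1ccc(C2N=C(SCc3ccc(F)cc3)NC(C)=C2C(=O)Nc2ccc(F)cc2)cc1OC`, gives 15.5%.
Compound 3, `CC1=C(C(=O)Nc2ccc([N+](=O)[O-])cc2)C(c2cccc([N+](=O)[O-])c2)N=C(SCc2ccc(Cl)cc2)N1`, gives 12.4%.

All three were tested in a functional assay on the whole organism (artery, strain albino) with Rattus norvegicus as the target, with a stated time of 120 min, at a dose of 10 mg/kg by the oral route; on this read-out higher numbers stand for more inhibition at the one dose given (going by the name of the read-out) and lower numbers for less inhibition. Compound 1 and compound 2 share one core and differ by fluoro in place of chloro on an aromatic carbon; this change gave no change at the digits printed from compound 1 to compound 2 (within the scatter). Compound 3 rests on a different core, and the difference between the two cores is not broken down here. Compound 4, `CC1=C(C(=O)Nc2ccc([N+](=O)[O-])cc2)C(c2cccc([N+](=O)[O-])c2)N=C(SCc2ccc(F)cc2)N1`, has not yet been measured; it differs from compound 3 by fluoro in place of chloro on an aromatic carbon, at the same place as in the earlier pair, so it is the same change. Because the earlier pair showed no change at the digits printed from compound 1 to compound 2 (within the scatter), the step from compound 3 to compound 4 is expected to be no change at the digits printed from compound 3 to compound 4 (within the scatter), resting only on that one earlier pair. Compound 4 is therefore estimated at 12.4%, expected between 3% and 22%.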

Compound 4, a percentage reported as inhibition, in the whole organism at one dose (the size of the read-out at that dose, not a potency): 13.4%
For compound 4 the middle estimate is 1 percentage points below the measured one; measured number inside the range.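

In this assay, going from 4-chlorobenzyl to 4-fluorobenzyl on the second core gave a number 1 percentage points higher from compound 3 to compound 4 (within the scatter). Set beside the earlier pair, the swap reads the same on both cores: the same change on two cores in this assay, no change at the digits printed (within the scatter) from compound 1 to compound 2 and a number 1 percentage points higher (within the scatter) from compound 3 to compound 4, 1 percentage points apart, within the scatter of two such steps

This suggests that, on these two cores, the swap leaves the read-out within the scatter, but it rests on just two pairs at a single dose and does not show that the same would hold on any other core.

As far as these compounds go, all four compounds carry a halogen at this place, so it remains open whether an amine or a carboxylic acid there would shift the number beyond the scatter. The same question stands for a longer chain in place of the benzyl group.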